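Swapping the aryl group on a weak cytotoxic compound

The source may hold more compounds than are shown below. What is called first, only, known or untested is meant among the compounds shown, and "the series" means these compounds.

Compound 1 `Cc1nc2c3ccccc3ccc2c2nc3c(ccc4ccccc43)c(-c3cccc([N+](=O)[O-])c3)c12` gives 25500 nM as its value
Compound 2 `COc1ccc(-c2c3ccc4ccccc4c3nc3c2c(C)nc2c4ccccc4ccc32)cc1` gives 66400 nM as its value
Compound 3 `Cc1nc2c3ccccc3ccc2c2nc3c(ccc4ccccc43)c(-c3cccc4ccccc34)c12` gives 12100 nM as its value

All three values come from a functional assay on AGS cells (Homo sapiens) for cytotoxicity, read by MTT assay, with a stated time of 48 h (a lower number here means a stronger inhibitor, a higher number a weaker inhibitor), and compound 2 has the highest number of the set, which makes it the weakest of the three, as both of its gaps to the others lie beyond the scatter.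

The next compound keeps the shared core and changes one group. Compound 4 `Cc1nc2c3ccccc3ccc2c2nc3c(ccc4ccccc43)c(-c3ccccc3Cl)c12` has 2-chlorophenyl in place of 4-methoxyphenyl on an aromatic carbon, opposite the ring nitrogen, and the count runs 2-chlorophenyl in place of 4-methoxyphenyl on an aromatic carbon in full.

Among the compounds with values here, three measured steps concern this same carbon. Replacing 4-methoxyphenyl with naphthalen-1-yl gave a 5.5-fold lower number from compound 2 to compound 3 (0.74 log units; beyond the scatter) as the largest of them. The 3-nitrophenyl group also sits on the lower side of 4-methoxyphenyl, shown by a 2.6-fold higher number from compound 1 to compound 2 (0.42 log units; beyond the scatter) read backwards. The two replacements themselves differ by a 2.1-fold lower number from compound 1 to compound 3 (0.32 log units; beyond the scatter) in this comparison. Within the data shown here, no measured compound carries a chlorine, so this evidence is only indirect.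

A modest step to a lower number is therefore expected in this assay for the new compound. The estimated step is a 2.6-fold lower number from compound 2 to compound 4 (0.41 log units; beyond the scatter) and remains an expectation. For compound 4 the estimate is 26000 nM with 10000 nM to 60000 nM as its expected range.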

Compound 4, half-maximal inhibitory concentration: 52500 nM
The estimate for compound 4 lay 2.0-fold (0.31 log units) below the measured number, and the stated range covers the measured number.
By their numbers in this assay, from the lowest: compound 3; then compound 1; then compounds 4 and 2 (each within the scatter of the next).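

In this assay, exchanging 4-methoxyphenyl for 2-chlorophenyl gives a 1.3-fold lower number from compound 2 to compound 4 (0.10 log units; within the scatter), so two phenyl rings that differ in both their substituent and its place on the ring cannot be told apart at this carbon opposite the ring nitrogen. The other two steps, a 2.1-fold higher number from compound 1 to compound 4 (0.31 log units; beyond the scatter) and a 4.3-fold higher number from compound 3 to compound 4 (0.64 log units; beyond the scatter), show that this carbon still responds to some changes: 2-chlorophenyl joins 4-methoxyphenyl on the higher side of the set, while 3-nitrophenyl and naphthalen-1-yl stay lower, and compound 3 remains the strongest of the four. No measurement at hand accounts for this grouping of the four aryl groups, so the numbers describe it without explaining it.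

Every group compared at this carbon is an aromatic ring, which leaves open how a plain phenyl ring, an amine, a carboxylic acid or a longer alkyl chain would behave there. As far as these compounds go, it also remains open whether 3-chlorophenyl or 4-chlorophenyl would match 2-chlorophenyl, and whether replacing the methyl group on the shared core would shift the numbers at all.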